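Nonyl chain in place of bromophenyl on a chalcone amide

The source may hold more compounds than are shown below. What is called first, only, known or untested is meant among the compounds shown, and "the series" means these compounds.

Among the measured compounds shown here, compound 1 `O=C(CN1CCC(Cc2ccccc2)CC1)Nc1ccc(C(=O)/C=C/c2cn(Cc3ccc(Br)cc3)nn2)cc1` is one of two compounds measured in a functional assay on MCF7 cells (Homo sapiens) for inhibition, read by MTT assay; a higher number here means a weaker inhibitor, a lower number a stronger inhibitor. In this assay compound 1 gives 54500 nM. For the measured compounds named here, the only other measured compound, compound 2 `CCCCCCCCn1cc(/C=C/C(=O)c2ccc(NC(=O)CN3CCN(C(=O)OC(C)(C)C)CC3)cc2)nn1`, gives 98400 nM in this assay; the gap between the two lies within the scatter of repeated measurements, so the numbers show no difference between them. Compound 3 `CCCCCCCCCCn1cc(/C=C/C(=O)c2ccc(NC(=O)CN3CCC(Cc4ccccc4)CC3)cc2)nn1` has not been measured. It differs from compound 1 in one place: nonyl in place of 4-bromophenyl on a saturated chain carbon bound to an aromatic nitrogen. Going by the values given here, no step between measured compounds touches this position, so there is nothing to guide the direction; compound 2 carries an octyl chain in the same region and stands within the scatter of compound 1. The step from compound 1 to compound 3 is therefore expected to be a 1.3-fold higher number from compound 1 to compound 3 (0.11 log units; within the scatter), no further than the scatter. Compound 3 is expected to give about 70000 nM in this assay, likely between 25000 nM and 200000 nM.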

Compound 3, half-maximal inhibitory concentration: 55200 nM
Compound 3: middle estimate off by 1.3-fold (0.10 log units), on the high side; measured number inside the range.
By their numbers in this assay, from the lowest: compounds 1, 3 and 2 (each within the scatter of the next).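

In this assay, this position now has its first direct comparison, a 1.0-fold higher number from compound 1 to compound 3 (0.01 log units; within the scatter), and the two compounds cannot be told apart. At this position, then, on a saturated chain carbon bound to an aromatic nitrogen, a nonyl chain with no ring and a 4-bromophenyl group carrying a six-membered aromatic ring give numbers within the scatter of each other in this assay. Nothing measured here bears on the reason for this result.

The compounds shown leave open whether the same holds for groups of another kind at this position, such as an amine or a carboxylic acid in place of nonyl. They also leave open how a much shorter chain, such as ethyl, or a plain phenyl without the bromine would read.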